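Pyrrolidine to dimethylamine on the sigma-2 side chain

The source may report more compounds than this note shows. Statements on the series, on what has been measured and on what is new or still open speak of the compounds shown alone.

Compounds measured so far:
compound 1 `CN(C)CC[C@H]1CCC[C@@H](c2ccccc2)C1` — 156 nM
compound 2 `CN(C)CCC1CCCC(c2ccccc2)C1` — 115 nM
compound 3 `c1ccc([C@H]2CCC[C@@H](CCN3CCCC3)C2)cc1` — 61 nM

Three compounds share one core, a saturated ring bearing a phenyl group and a two-carbon chain that ends in a basic amine. In an assay on membranes from liver for displacement of a labelled ligand from Sigma intracellular receptor 2 (Rattus norvegicus), read by scintillation counting, with a stated time of 120 min (a higher number here means a weaker inhibitor, a lower number a stronger inhibitor), compound 3 gives 61 nM, the lowest number of the three. Against compound 2 the gap is within the scatter; against compound 1 it lies beyond it. Going by the values given here, the only one-place step measured, a 1.4-fold lower number from compound 1 to compound 2 (0.13 log units; within the scatter), concerns drawn configuration alone, and the difference in how the two are drawn (the fact that one of compounds 1 and 2 is drawn with a defined configuration and the other without, at the place where they differ) is the only evidence on it.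

Compound 4 `CN(C)CC[C@@H]1CCC[C@H](c2ccccc2)C1` is made from compound 3 by dimethylamino in place of pyrrolidin-1-yl on a saturated chain carbon, two bonds along the chain from a saturated ring carbon. Among the compounds with values here, no measured step changes the amine itself, so the expectation rests on the spread of all three numbers. Compound 1 and compound 2, both carrying dimethylamino, sit higher than compound 3, which suggests a modestly weaker result. Compound 4 is therefore estimated at 100 nM in this assay, within 45 nM to 220 nM, an expected step of a 1.6-fold higher number from compound 3 to compound 4 (0.21 log units; within the scatter).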

Compound 4, inhibition constant: 76 nM
Estimate against measurement, compound 4: 1.3-fold (0.12 log units) above, and the stated range covers the measured number.
By their numbers in this assay, from the lowest: compounds 3, 4, 2 and 1 (each within the scatter of the next, the first and the last beyond it).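

In this assay, the amine itself is now tested directly, and the swap from pyrrolidin-1-yl to dimethylamino gives a step within the scatter (a 1.2-fold higher number from compound 3 to compound 4 (0.10 log units; within the scatter)), so these two amines cannot be told apart here. Going by these compounds alone, the mirror-image pair gives the first one-place step beyond the scatter, though only a modest one (a 2.1-fold lower number from compound 1 to compound 4 (0.31 log units; beyond the scatter)), and the sole difference available to account for it is this: (the fact that compounds 1 and 4 differ only in the configuration as drawn). Within the data shown here, the remaining step stays within the scatter (a 1.5-fold lower number from compound 2 to compound 4 (0.18 log units; within the scatter)), so the drawn configuration adds no measurable separation here, and the only evidence on that comparison is this: (the fact that one of compounds 2 and 4 is drawn with a defined configuration and the other without, at the place where they differ).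

Going by these compounds, whether an amine such as piperidin-1-yl or morpholin-4-yl, or a longer chain, would stay in this range remains open. Also open, on these data alone, is whether the gap between mirror images holds with pyrrolidin-1-yl in place of dimethylamino.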